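This account rests on a few compounds, and the source may have more. Where it says the series, first, only, none or still open, it means among the compounds named here.

Of the compounds shown here, three have numbers so far in a functional assay on KB cells (Homo sapiens) for antiproliferative activity, read by MTT assay; a lower number here means a stronger inhibitor, a higher number a weaker inhibitor. Compound 1 `Fc1ccc(N2CCN(c3nc(-n4ccc5ccccc54)c4ccccc4n3)CC2)cc1` gives 50 ug/mL, and compound 2 `COc1ccc(-c2nc(N3CCNCC3)nc3ccccc23)c(OC)c1` gives 50 ug/mL. Compound 3 `c1ccc2c(c1)ccn2-c1nc(N2CCNCC2)nc2ccccc12` gives 4 ug/mL, the lowest of the three numbers, which makes it the strongest inhibitor of this small set.

Compound 4 `c1ccc(N2CCN(c3nc(-n4ccc5ccccc54)c4ccccc4n3)CC2)cc1` has not yet been measured. It keeps the core of compound 3 and changes one place: phenyl in place of hydrogen on an amine nitrogen in a ring.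

For the measured compounds named here, only one measured step bears directly on this change. It is a 13-fold lower number from compound 1 to compound 3 (1.10 log units; beyond the scatter), a large step that came with hydrogen in place of 4-fluorophenyl on that same nitrogen. Compound 4 goes the opposite way, adding a group rather than removing one. Phenyl and 4-fluorophenyl are closely related groups, though no measured pair separates them, and this single step is thin evidence.

A large move towards a higher number is therefore expected in this assay, and the estimated step is a 10-fold higher number from compound 3 to compound 4 (1.00 log units; beyond the scatter). For compound 4 the estimate is 40 ug/mL, with an expected range from 15 ug/mL to 80 ug/mL.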

Compound 4, half-maximal inhibitory concentration: 50 ug/mL
The estimate for compound 4 lay 1.3-fold (0.10 log units) below the measured number; the measured number falls inside the stated range.
By their numbers in this assay, from the lowest: compound 3; then compounds 1, 2 and 4 (each within the scatter of the next).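

In this assay, placing a phenyl on the amine nitrogen of the six-membered ring gives a 13-fold higher number from compound 3 to compound 4 (1.10 log units; beyond the scatter), which shows that a plain phenyl ring at this position goes with a much weaker result, with no fluoro needed. For the compounds shown here, the fluoro itself has no visible effect here: swapping it for hydrogen gives no change at the digits printed from compound 1 to compound 4 (within the scatter), and that comparison is the one the earlier compounds could not make. The earlier large step, a 13-fold lower number from compound 1 to compound 3 (1.10 log units; beyond the scatter), can therefore be read as tied to the presence of the aromatic ring on this nitrogen rather than to its fluoro, though this rests only on compounds 1, 3 and 4.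

No measurement shown here explains why a phenyl on this nitrogen goes with the weaker number. On these data alone, it also remains open whether a methyl, an acetyl or a benzyl on the same nitrogen would stay close to compound 3 at 4 ug/mL or move as far as the phenyl does, so how much of the free amine nitrogen can be changed is unknown.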